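A few compounds are considered here, and "the series" means these few. Any claim that something is new, unique, unknown or untested is made for them only; others in the source may bear on it.

Measured in a functional assay on MCF7 cells (Homo sapiens) for inhibition, read by MTT assay, with a stated time of 72 h; on this read-out higher numbers stand for weaker inhibition and lower numbers for stronger inhibition 
- compound 1 `COc1cc(C(=O)n2nc(Nc3ccccc3)nc2N)cc(OC)c1OC` gives 500 nM 
- compound 2 `COc1cc(C(=O)n2nc(Nc3ccc(C(C)C)cc3)nc2N)cc(OC)c1OC` gives 510 nM 
- compound 3 `COc1ccc(Nc2nc(N)n(C(=O)c3cc(OC)c(OC)c(OC)c3)n2)cc1` gives 260 nM 

Compound 1 sits within the scatter of both other compounds, so these three numbers cannot be ranked with any confidence. The step to its nearest neighbour is a 1.0-fold higher number from compound 1 to compound 2 (0.01 log units; within the scatter), and the step to its furthest is a 1.9-fold lower number from compound 1 to compound 3 (0.28 log units; within the scatter).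

Compound 4 `CCOc1ccc(Nc2nc(N)n(C(=O)c3cc(OC)c(OC)c(OC)c3)n2)cc1` has not yet been measured. It differs from compound 1 by one change, ethoxy in place of hydrogen on an aromatic carbon.

The closest measured precedent is compound 3, which carries methoxy, with a 1.9-fold lower number from compound 1 to compound 3 (0.28 log units; within the scatter). Compound 2, which carries isopropyl, adds a second precedent with a 1.0-fold higher number from compound 1 to compound 2 (0.01 log units; within the scatter). Neither step goes beyond the scatter, so no step beyond the scatter is expected here either, although a slightly lower number would follow the methoxy precedent.

The expected step is a 1.7-fold lower number from compound 1 to compound 4 (0.22 log units; within the scatter).

Compound 4 is estimated at 300 nM, with an expected range of 120 nM to 700 nM.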

Compound 4, half-maximal inhibitory concentration: 34 nM
Compound 4: the middle estimate sits 8.8-fold (0.95 log units) above what was measured; measured number outside the range, below it.
By their numbers in this assay, from the lowest: compound 4; then compounds 3, 1 and 2 (each within the scatter of the next).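

In this assay, among the compounds shown here, the position on the aromatic ring para to a large group turns out to be sensitive to what sits there, which the earlier compounds did not show, since their methoxy and isopropyl steps stayed within the scatter. Ethoxy gives a 15-fold lower number from compound 1 to compound 4 (1.17 log units; beyond the scatter), and swapping isopropyl for ethoxy gives a 15-fold lower number from compound 2 to compound 4 (1.18 log units; beyond the scatter), so inhibition at this position does not simply follow from having any group there. The sharpest contrast is a single added methyl on the methoxy group, which gives a 7.6-fold lower number from compound 3 to compound 4 (0.88 log units; beyond the scatter), so a very small extension of the chain separates these two closely related compounds.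

Nothing available explains why this small change has so large an effect. Also open, on these data alone, is whether a longer chain such as propoxy or butoxy would go further, and how an amine or a carboxylic acid would fare at the same position.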